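The source may hold more compounds than are shown below. What is called first, only, known or untested is meant among the compounds shown, and "the series" means these compounds.

Measured so far:
- compound 1 `O=C1O/C(=C\Cn2c(=O)[nH]c(=O)[nH]c2=O)C(OCc2ccccc2)=C1OCc1ccccc1` — in a functional assay on SW-620 cells (Homo sapiens) for inhibition, read by MTT assay, with a stated time of 72 h (on this read-out lower numbers stand for stronger inhibition and higher numbers for weaker inhibition), compound 1 gives only a limit, > 100000 nM.
- compound 2 `NC1(CCn2ccc(=O)[nH]c2=O)OC(=O)C(OCc2ccccc2)=C1OCc1ccccc1` — in this assay compound 2 also gives only a limit, > 100000 nM.
- compound 3 `Nc1ccn(C[C@H](O)[C@H]2OC(=O)C(OCc3ccccc3)=C2OCc2ccccc2)c(=O)n1` — in this assay compound 3 likewise gives only a limit, > 100000 nM.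

Compound 1 therefore stands at the top of the measured range, and so do the other two: the limit of > 100000 nM in this assay, at which 3 of the 3 values shown sit. No pair of measured compounds differs in one place, so no measured step is on hand to set the scale of a change, and no cause for the shared limit can be pointed to.

Compound 4 `Nc1ncn(C/C=C2\OC(=O)C(OCc3ccccc3)=C2OCc2ccccc2)c(=O)n1` is the next compound. It differs from compound 1 by a group of 8 heavy atoms (3 carbon, 4 nitrogen, 1 oxygen; one six-membered aromatic ring with 3 hetero atoms) in place of a group of 9 heavy atoms (3 carbon, 3 nitrogen, 3 oxygen; one six-membered aromatic ring with 3 hetero atoms), on a saturated chain carbon bound to a double-bonded chain carbon. The entering group, like the leaving one, carries one six-membered aromatic ring with 3 hetero atoms, and the place, a saturated chain carbon bound to a double-bonded chain carbon, is unchanged. Among the measured compounds shown here, with three compounds resting at the limit and no step to draw on, the expectation is no movement beyond the scatter: the expected step of a number no higher from compound 1 to compound 4 (the limit leaves the size open) is essentially flat. Compound 4 is expected to sit at 100000 nM, within 30000 nM to 300000 nM, most likely reported again only as a limit.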

Compound 4, half-maximal inhibitory concentration: 5620 nM
The estimate for compound 4 lay 18-fold (1.25 log units) above the measured number; measured number outside the range, below it.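

On a saturated chain carbon bound to a double-bonded chain carbon, a group of 8 heavy atoms (3 carbon, 4 nitrogen, 1 oxygen) in place of a group of 9 heavy atoms (3 carbon, 3 nitrogen, 3 oxygen), both with one six-membered aromatic ring with 3 hetero atoms, gives in this assay an at least 17-fold lower number from compound 1 to compound 4 (1.25 log units; beyond the scatter). Among the compounds shown here, compound 1 carries only a limit, so this step is a floor, and it shows that with the rest of the core of compound 1 held, the group at this place can move the read-out, which the earlier compounds could not show. Compound 4 is the only one of the compounds shown to give a number rather than a limit: the limit of > 100000 nM in this assay, at which 3 of the 4 values shown sit.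

This single pair cannot tell which difference in the group goes with the step, whether the change in ring atoms, the 1 double bond outside aromatic rings in place of 3, or the changed donor and acceptor counts. Also open, from the compounds shown here alone, is how the number at this place responds to an amine on a different ring or to a longer chain carrying the group of compound 4.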